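A few compounds are considered here, and "the series" means these few. Any claim that something is new, unique, unknown or untested is made for them only; others in the source may bear on it.

Measured compounds:
- compound 1, `CC1=CC[C@H]2[C@@H]1CC=C(C)[C@@H](CC[C@H]1[C@]3(C)CC[C@H](O)C(C)(C)O[C@H]3CC[C@@]1(C)O)C2(C)C`: > 50000 nM
- compound 2, `CC1=CC[C@H]2[C@@H]1CC=C(C)[C@@H](CC[C@H]1[C@]3(C)CC[C@H](OC(=O)c4ccccc4)C(C)(C)O[C@H]3CC[C@@]1(C)O)C2(C)C`: 18400 nM
- compound 3, `CC1=CC[C@H]2[C@H](CC[C@]2(C)O)C(C)(C)[C@@H]1CC[C@H]1[C@]2(C)CC/C(=N/O)C(C)(C)O[C@H]2CC[C@@]1(C)O`: 42700 nM

All three were tested in a functional assay on MDA-MB-231 cells (Homo sapiens) for antiproliferative activity, read by MTT assay, with a stated time of 72 h; on this read-out higher numbers stand for weaker inhibition and lower numbers for stronger inhibition. For compound 1 the result is not a number but a limit of the assay, > 50000 nM. Compound 2 differs from compound 1 in one place only, (benzoyl in place of hydrogen on an oxygen on a saturated carbon), and that change gives an at least 2.7-fold lower number from compound 1 to compound 2 (0.43 log units; beyond the scatter). The size of that step is known only as a lower bound, since compound 1 sits at the limit of > 50000 nM in this assay, at which 1 of the 3 values shown sits.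

Compound 3 is built on a different core, and the difference between the two cores is not broken down here. In this assay compound 3 gives 42700 nM, which stands as the highest of the two plain numbers, above compound 2.

Compound 4, `CC1=CC[C@H]2[C@H](CC[C@]2(C)O)C(C)(C)[C@@H]1CC[C@H]1[C@]2(C)CC/C(=N/OC(=O)c3ccccc3)C(C)(C)O[C@H]2CC[C@@]1(C)O`, has not been measured. It is related to compound 3 by benzoyl in place of hydrogen on an oxygen. For the measured compounds named here, this is the same kind of change as the one from compound 1 to compound 2, but not the same: in compound 1 the oxygen sits on a saturated carbon whose other neighbours are a saturated ring carbon, whereas in compound 3 the oxygen's other neighbour is a double-bonded nitrogen. Going by the values given here, the only measured example of this kind of change lowered the number, so a similar fall is expected here, giving an estimated step of a 3.1-fold lower number from compound 3 to compound 4 (0.48 log units; beyond the scatter). On that basis compound 4 is expected to give about 14000 nM in this assay, most likely between 5000 nM and 40000 nM.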

Compound 4, half-maximal inhibitory concentration: 27400 nM
Beside the measured number, compound 4's estimate is 2.0-fold (0.29 log units) below it; measured number inside the range.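

In this assay, putting benzoyl in place of hydrogen on an oxygen whose other neighbour is a double-bonded nitrogen gives a 1.6-fold lower number from compound 3 to compound 4 (0.19 log units; within the scatter), so on this core the change cannot be told apart from the ordinary spread of repeated measurements. Set beside the earlier example, the comparison reads: the same change on two cores in this assay, an at least 2.7-fold lower number (0.43 log units; beyond the scatter) from compound 1 to compound 2 and a 1.6-fold lower number (0.19 log units; within the scatter) from compound 3 to compound 4; the limit leaves it open whether they differ The pair of steps therefore shows a clear effect of the change only on the core of compound 1, where the oxygen sits on a saturated carbon, but it does not show that the effect truly differs from one core to the other.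

As far as these compounds go, compound 1 gives > 50000 nM, which is a limit of the assay and not a number, so the full size of its step remains unknown. The compounds shown carry only hydrogen or benzoyl on this oxygen, which leaves open how an acetyl group, a longer chain or a benzoyl ring bearing an amine or a carboxylic acid would behave on either core in this assay.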